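A few compounds are considered here, and "the series" means these few. Any claim that something is new, unique, unknown or untested is made for them only; others in the source may bear on it.

Of the compounds shown here, two have been measured in an assay on VSM-A10 cells for antagonist activity at Endothelin-1 receptor (Rattus norvegicus); a higher number here means a weaker inhibitor, a lower number a stronger inhibitor. Compound 2, `Cc1noc(NS(=O)(=O)c2cccc3c(NCc4ccccc4)cccc23)c1C`, gives 590 nM in this assay. Compound 1, `Cc1noc(N(CC(=O)O)S(=O)(=O)c2ccc(N)cc2)c1C`, gives only a limit in this assay, > 32000 nM. For the measured compounds named here, compound 2 therefore holds the only actual number, while the other value is a limit, as the limit of > 32000 nM in this assay, at which 1 of the 2 values shown sits, records. Compound 3, `Cc1noc(NS(=O)(=O)c2cccc3c(N/C(S)=N/c4ccccc4)cccc23)c1C`, has not yet been measured. Compared with compound 2, the change is a group of 9 heavy atoms (7 carbon, 1 nitrogen, 1 sulfur; one six-membered aromatic ring of carbon only) in place of a group of 7 heavy atoms (7 carbon; one six-membered aromatic ring of carbon only), on a nitrogen on an aromatic ring. In words, a group of 9 heavy atoms (7 carbon, 1 nitrogen, 1 sulfur; one six-membered aromatic ring of carbon only) takes the place of a group of 7 heavy atoms (7 carbon; one six-membered aromatic ring of carbon only), on a nitrogen on an aromatic ring. Going by the values given here, no measured pair shows a change of this kind, so no size of step can be read from the data, and the direction is open. The expected step, a 1.7-fold higher number from compound 2 to compound 3 (0.23 log units; within the scatter), is estimated to lie within the usual scatter or only a little beyond it. The estimate for compound 3 is 1000 nM, with an expected range from 250 nM to 4000 nM.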

Compound 3, half-maximal inhibitory concentration: 150 nM
Estimate against measurement, compound 3: 6.7-fold (0.82 log units) above, and the stated range ends above it.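

In this assay, putting the new group in place of benzyl on the nitrogen on an aromatic ring gives a 3.9-fold lower number from compound 2 to compound 3 (0.59 log units; beyond the scatter), so compound 3 is the stronger inhibitor of this pair and this position clearly responds to a change of group. Both groups keep one six-membered aromatic ring of carbon only, while the entering group adds a nitrogen, a sulfur, a double bond outside aromatic rings, a hydrogen-bond donor and a hydrogen-bond acceptor, so the difference lies in the atoms added rather than in the ring. Nothing measured here bears on why the number falls.

This single step cannot show whether the sulfur, the added nitrogen or the two together account for the change, and a urea with oxygen in place of the sulfur, or a longer chain in place of benzyl, would help to separate these. Also open, as far as these compounds go, is whether a chlorine or a methoxy group on the six-membered ring of the entering group would move the number further.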